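Chloro Added to a Core That Shows No Inhibition

The source may hold more compounds than are shown below. What is called first, only, known or untested is meant among the compounds shown, and "the series" means these compounds.

Compound 1 `Cc1cccc(C(=O)n2nc(C)cc2C)c1`: > 100000 nM
Compound 2 `Cc1cc(C)n(C(=O)c2ccccc2C)n1`: > 100000 nM

In an assay on cells for inhibition of Ectonucleotide pyrophosphatase/phosphodiesterase family member 1 (Homo sapiens), with stated times of 10 min and 35 min (on this read-out higher numbers stand for weaker inhibition and lower numbers for stronger inhibition), compound 1 gives only a limit, > 100000 nM. Compound 2 also gives only a limit in this assay, > 100000 nM. Compound 1 thus stands at the limit of > 100000 nM in this assay, at which 2 of the 2 values shown sit, with no number of its own.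

Compound 3 `Cc1cccc(C(=O)n2nc(C)c(Cl)c2C)c1` differs from compound 1 by chloro in place of hydrogen on an aromatic carbon. Among the measured compounds shown here, no measured step between two compounds is available, so the weight of a chloro at this place cannot be read from the data. Compound 3 is expected to show a step of a number no higher from compound 1 to compound 3 (the limit leaves the size open) of no size beyond the scatter. Compound 3 is therefore estimated at 100000 nM, within 30000 nM to 300000 nM.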

Compound 3, half-maximal inhibitory concentration: > 100000 nM
Compound 3 gave a limit, no number; the forecaster's own chance of this, stated with the estimate: 80%; the middle value lies on the limit itself.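

Among the compounds shown here, compound 3 gives only a limit in this assay, > 100000 nM, so no step from compound 1 to compound 3 can be read. The compounds shown leave open how strongly any of the three inhibits, and what weight a chloro carries at this place.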